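Notes on the series: from compound 2 to compound 3

A few compounds are considered here, and "the series" means these few. Any claim that something is new, unique, unknown or untested is made for them only; others in the source may bear on it.

Two compounds have been run. Compound 1 `CC(=O)c1cc(-c2ccccc2)cc2cc(-c3ccccc3)[nH]c12` is the unsubstituted parent. In a functional assay on MCF7 cells (Homo sapiens) for cytotoxicity, read by MTT assay, with a stated time of 2 days (on this read-out lower numbers stand for higher toxicity in this test and higher numbers for lower toxicity in this test), compound 1 reaches the limit of the test, > 100000 nM, and gives no number; this is the case described by the limit of > 100000 nM in this assay, at which 1 of the 2 values shown sits. Compound 2 `COc1ccc(-c2cc(C(C)=O)c3[nH]c(-c4ccccc4)cc3c2)cc1` adds a methoxy on an aromatic carbon, and in this assay compound 2 gives 47800 nM. Among the compounds with values here, that is the only number in the set so far; the other value is a limit. Within the data shown here, the one measured step is an at least 2.0-fold lower number from compound 1 to compound 2 (0.32 log units; beyond the scatter). Compound 3 `CC(=O)c1cc(/C=C/c2ccccc2)cc2cc(-c3ccccc3)[nH]c12` has not been measured. It differs from compound 2 by 2-phenylethenyl in place of 4-methoxyphenyl on an aromatic carbon. The step from compound 1 to compound 2 is the only one that touches the same place on the shared core, and it runs the other way, since the methoxy gained there is lost again in compound 3 together with the ring that carried it. The measured record therefore gives no firm guide to size or sign; a number near that of compound 2 and a drift back toward the limit are both plausible. Compound 3 is expected to give about 60000 nM in this assay, within 15000 nM to 200000 nM. The expected step is a 1.3-fold higher number from compound 2 to compound 3 (0.10 log units; within the scatter), not clearly beyond the scatter.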

Compound 3, concentration lethal to 50% of the cells: > 100000 nM
Compound 3: no number, only a limit; the forecaster's own chance of this, stated with the estimate: 35%; middle value at least 1.6-fold (0.22 log units) from the limit.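

Within the data shown here, at this position, on an aromatic carbon meta to an acetyl group, 2-phenylethenyl in place of 4-methoxyphenyl gives an at least 2.0-fold higher number from compound 2 to compound 3 (0.32 log units; beyond the scatter) in this assay, so the only measurable value in the set does not survive this change. The leaving and entering groups have the same count of heavy atoms and each holds one six-membered aromatic ring of carbon only, so those shared features alone do not preserve that value; the counted differences are the oxygen and hydrogen-bond acceptor of 4-methoxyphenyl and the double bond outside aromatic rings in 2-phenylethenyl. The step from compound 1 to compound 3, 2-phenylethenyl in place of phenyl, cannot be read: the limit of > 100000 nM in this assay, at which 2 of the 3 values shown sit.

The compounds shown do not separate the contribution of the methoxy from that of the double bond, since the two differ together in this change. As far as these compounds go, how an amine in place of the methoxy, or a methoxy on the ring of 2-phenylethenyl, would read in this assay stays open.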